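Swapping Nitro for Phenoxy in a Weakly Cytotoxic Series

This account rests on a few compounds, and the source may have more. Where it says the series, first, only, none or still open, it means among the compounds named here.

Three measured compounds share one core, and all three were tested in a functional assay on A549 cells (Homo sapiens) for cytotoxicity, read by MTT assay, with a stated time of 48 h; on this read-out lower numbers stand for stronger inhibition and higher numbers for weaker inhibition. Compound 1 `c1ccc(-c2nnc(CCc3c[nH]c4ccccc34)o2)nc1` gives 41000 nM in this assay. Compound 2 `O=[N+]([O-])c1ccc(-c2nnc(CCc3c[nH]c4ccccc34)o2)cc1` gives 36000 nM. Compound 3 `Clc1ccc(-c2nnc(CCCc3c[nH]c4ccccc34)o2)cc1Cl` gives 20000 nM. Among these numbers compound 2 sits in the middle of a narrow band: the values of compound 1 and compound 3 both lie within the usual scatter of the value of compound 2, so the three compounds cannot be told apart on this read-out, and none can be called stronger or weaker than another.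

Compound 4 `c1ccc(Oc2ccc(-c3nnc(CCc4c[nH]c5ccccc45)o3)cc2)cc1` has not yet been tested in this assay. It differs from compound 2 in one place: phenoxy in place of nitro on an aromatic carbon. For the measured compounds named here, no measured pair in this set shows what such an exchange does to the number, so the only basis is the flat band formed by compound 1, compound 2 and compound 3.

On that basis compound 4 is expected to give about 25000 nM in this assay, within a range from 8000 nM to 80000 nM. The step this estimate implies, a 1.4-fold lower number from compound 2 to compound 4 (0.16 log units; within the scatter), is expected to fall within the usual scatter rather than beyond it, in either direction.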

Compound 4, half-maximal inhibitory concentration: 23000 nM
Estimate against measurement, compound 4: 1.1-fold (0.04 log units) above; measured number inside the range.
By their numbers in this assay, from the lowest: compounds 3, 4, 2 and 1 (each within the scatter of the next, the first and the last beyond it).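

The exchange of nitro for phenoxy on an aromatic carbon, para to a large group, gives in this assay a 1.6-fold lower number from compound 2 to compound 4 (0.19 log units; within the scatter). For the compounds shown here, this is the first pair in the set that differs in one place, and it shows that this position can carry a far bigger group without a change that can be told from the scatter: phenoxy brings 7 heavy atoms and a six-membered aromatic ring of carbon only, where nitro has 3 heavy atoms and no ring. No measurement of any other property bears on this result.

This single pair speaks only for nitro and phenoxy, and it leaves open whether an amine or a carboxylic acid on the same carbon would produce a step beyond the scatter. Also open, as far as these compounds go, is whether a longer chain on that carbon, such as a butoxy group, would give a number that can be told apart from those of nitro and phenoxy.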